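Replacing phenyl with imidazolyl on the shared core

This account rests on a few compounds, and the source may have more. Where it says the series, first, only, none or still open, it means among the compounds named here.

Compound 1 `CC(/N=c1\c(O)c(O)\c1=N/c1ccc(C#N)cc1)C(C)(C)C`: 520 nM
Compound 2 `CC(/N=c1\c(O)c(O)\c1=N/c1ccc(-c2ccccc2)cc1)C(C)(C)C`: > 30000 nM

Both compounds were tested in a functional assay for inhibition, with Rattus norvegicus as the target; on this read-out lower numbers stand for stronger inhibition and higher numbers for weaker inhibition. In this assay compound 1 gives 520 nM.

Compound 2 gives > 30000 nM, which is a limit and not a number. Its place on the scale is therefore (the limit of > 30000 nM in this assay, at which 1 of the 2 values shown sits).

Compound 3 `CC(/N=c1\c(O)c(O)\c1=N/c1ccc(-n2ccnc2)cc1)C(C)(C)C` keeps the shared core, with 1H-imidazol-1-yl in place of phenyl on an aromatic carbon.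

Among the compounds with values here, one measured step bears on this change, at the same place on the ring. It is large and beyond the scatter: an at least 57-fold higher number from compound 1 to compound 2 (1.76 log units; beyond the scatter). That step suggests that the group here can strongly affect the read-out, so a sizeable move towards stronger inhibition is expected. The expected step is an at least 10-fold lower number from compound 2 to compound 3 (1.00 log units; beyond the scatter). For compound 3 the estimated value is 3000 nM, with an expected range of 300 nM to 30000 nM.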

Compound 3, half-maximal inhibitory concentration: > 30000 nM
Compound 3: only a limit was reported; the forecaster's own chance of this, stated with the estimate: 25%; at least 10-fold (1.00 log units) between middle value and limit.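

Putting 1H-imidazol-1-yl in place of cyano on this aromatic carbon gives, in this assay, an at least 57-fold higher number from compound 1 to compound 3 (1.76 log units; beyond the scatter). A second ring group at this place thus also fails to keep the readable value of the nitrile, and this time the ring is a five-membered aromatic ring with 2 hetero atoms rather than one of carbon only. Compound 2 and compound 3 both give a limit and not a number, so the step between them cannot be read and the two groups cannot be ordered: the limit of > 30000 nM in this assay, at which 2 of the 3 values shown sit.

As far as these compounds go, it remains open how far beyond that limit compound 2 and compound 3 lie. From the compounds shown here alone, it is also open whether an amine or a carboxylic acid at this place would give a readable number, as the nitrile of compound 1 does.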